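Sulfonyl variation on the pyrazoline nitrogen: methyl to 4-cyanophenyl

The compounds below may be only part of what the source reports. "The series", "measured", "known", "first", "only" and "open" are said of these compounds alone.

Measured so far:
compound 1, `CN1CCN(c2ccc(C3=NN(C(=O)/C=C/c4ccccc4)C(c4ccc(N(C)C)cc4)C3)cc2)CC1`, 71%
compound 2, `CN1CCN(c2ccc(C3=NN(S(C)(=O)=O)C(c4ccc(N(C)C)cc4)C3)cc2)CC1`, -18.5%

Among the measured compounds shown here, in a functional assay on HCC1806 cells (Homo sapiens) for inhibition, read by sulforhodamine B assay, tested at 10 uM (a lower number here means less inhibition, a higher number more inhibition at the concentration tested (going by the name of the read-out)), compound 2 gives -18.5%, the lower of the two numbers; compound 1 gives 71%, and the only measured step, a number 89.5 percentage points lower from compound 1 to compound 2 (beyond the scatter), lies beyond the scatter. Compound 3, `CN1CCN(c2ccc(C3=NN(S(=O)(=O)c4ccc(C#N)cc4)C(c4ccc(N(C)C)cc4)C3)cc2)CC1`, has not yet been measured. It differs from compound 2 by 4-cyanophenyl in place of methyl on a sulfonyl sulfur.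

For the measured compounds named here, no measured step alters the substituent on the sulfonyl sulfur; the one step available concerns an exchange of the whole group on the ring nitrogen and does not bear directly on this change. Going by the values given here, it shows only that a change at this position can move the number in the read-out by a large amount. Compound 3 is therefore expected, with wide uncertainty, to give 10%, within -20% to 45%. The step this estimate implies, a number 28.5 percentage points higher from compound 2 to compound 3 (beyond the scatter), is expected to be an increase, but one not far beyond the scatter.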

Compound 3, a percentage reported as inhibition, at one concentration (the size of the read-out at that concentration, not a potency): 99.8%
The estimate for compound 3 lay 89.8 percentage points below the measured number; the measured number lies above the stated range.
By their numbers in this assay, from the lowest: compound 2; then compound 1; then compound 3.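

In this assay, the group on the sulfonyl sulfur alone decides the outcome: 4-cyanophenyl in place of methyl gives a number 118.3 percentage points higher from compound 2 to compound 3 (beyond the scatter), so the low number of compound 2 does not follow from sulfonyl substitution on the ring nitrogen as such. Nor does a sulfonyl group have to fall short of the (2-phenylethenyl)carbonyl group, since the exchange for (4-cyanophenyl)sulfonyl gives a number 28.8 percentage points higher from compound 1 to compound 3 (beyond the scatter). No measured evidence accounts for the size of either step.

The compounds shown do not separate the contribution of the nitrile from that of the aromatic ring; a plain phenylsulfonyl group or a 4-aminophenylsulfonyl group would address that. On these data alone, these numbers also come from a single concentration, so how the compounds rank in potency remains open.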